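This account rests on a few compounds, and the source may have more. Where it says the series, first, only, none or still open, it means among the compounds named here.

Measured in an assay on CHO cells for displacement of a labelled ligand from Substance-P receptor (Homo sapiens); on this read-out lower numbers stand for stronger inhibition and higher numbers for weaker inhibition:
compound 1 `C[C@@H](O[C@@H]1CN(C(=O)C(C)(C)C)C[C@H]1c1ccccc1)c1cc(C(F)(F)F)cc(C(F)(F)F)c1`: 0.18 nM
compound 2 `CC(=O)N1CCC(C(=O)N2C[C@@H](O[C@H](C)c3cc(C(F)(F)F)cc(C(F)(F)F)c3)[C@H](c3ccc(F)cc3)C2)CC1`: 0.07 nM
compound 3 `C[C@@H](O[C@@H]1CN(C(=O)[C@@H]2CCC(=O)N2C)C[C@H]1c1ccc(F)cc1)c1cc(C(F)(F)F)cc(C(F)(F)F)c1`: 0.12 nM

Compound 1 gives the highest number of the three; compound 3 sits within the scatter of compound 1, whereas compound 2 lies beyond it, with the lower number. Within the data shown here, the one single-point step among the measured compounds, a 1.7-fold higher number from compound 2 to compound 3 (0.23 log units; within the scatter), swaps one group on a carbonyl carbon for another and stays within the scatter.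

Compound 4 `C[C@@H](O[C@@H]1CN(C2=CC(=O)CC(C)(C)C2)C[C@H]1c1ccccc1)c1cc(C(F)(F)F)cc(C(F)(F)F)c1` is not yet measured. It differs from compound 1 in one place: 5,5-dimethyl-3-oxocyclohex-1-en-1-yl in place of (tert-butyl)carbonyl on an amine nitrogen in a ring. Among the measured compounds shown here, no measured step touches the group on the amine nitrogen in the ring; the step from compound 2 to compound 3 varies a group on the carbonyl carbon and not the carbonyl itself, so it bears only loosely on this change. Since the carbonyl on the amine nitrogen is lost and a ring enters in its place, a modest rise in the number is expected for compound 4, of about a 2.8-fold higher number from compound 1 to compound 4 (0.44 log units; beyond the scatter), with wide uncertainty. The estimate for compound 4 in this assay is 0.5 nM, within 0.12 nM to 2.5 nM.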

Compound 4, half-maximal inhibitory concentration: 0.13 nM
The estimate for compound 4 lay 3.8-fold (0.59 log units) above the measured number, within the range that was stated.
By their numbers in this assay, from the lowest: compounds 2, 3, 4 and 1 (each within the scatter of the next, the first and the last beyond it).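

Among these compounds, on the amine nitrogen in the ring, 5,5-dimethyl-3-oxocyclohex-1-en-1-yl replaces (tert-butyl)carbonyl with a 1.4-fold lower number from compound 1 to compound 4 (0.14 log units; within the scatter) in this assay, giving the first reading on the group attached to this nitrogen rather than on a group on the carbonyl carbon. In this pair, the carbonyl directly on the nitrogen can therefore be lost and a six-membered carbon ring introduced, while the result stays within the scatter of compound 1. Nothing available explains why the two groups read alike.

The compounds shown leave open how a benzyl group, a longer alkyl chain or a carboxylic acid on that nitrogen would read. They also leave open whether 5,5-dimethyl-3-oxocyclohex-1-en-1-yl would read the same with a 4-fluorophenyl group on the shared core.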